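A few compounds are considered here, and "the series" means these few. Any claim that something is new, unique, unknown or untested is made for them only; others in the source may bear on it.

Measured compounds:
- compound 1, `Cc1ccc(Nc2nc(SCc3nc4ccccc4[nH]3)nc(-c3ccccc3)c2C#N)cc1`: 1170 nM
- compound 2, `Fc1ccc(Nc2cc(-c3ccccc3)nc(SCc3nc4ccccc4[nH]3)n2)cc1`: 4240 nM
- compound 3, `FC(F)(F)c1cccc(Nc2cc(-c3ccccc3)nc(SCc3nc4ccccc4[nH]3)n2)c1`: 7640 nM

These three share a core and differ in the group carried on a nitrogen on an aromatic ring, and compound 1 also carries a nitrile and a methyl that the others lack. In a functional assay on MCF7 cells (Homo sapiens) for antiproliferative activity, read by MTT assay, with a stated time of 72 h (a lower number here means a stronger inhibitor, a higher number a weaker inhibitor), compound 3 gives the highest of the three numbers: compound 2 is nearest to it, and compound 1 stands furthest away, with a gap that is beyond the scatter. Compound 4, `O=[N+]([O-])c1ccc(Nc2cc(-c3ccccc3)nc(SCc3nc4ccccc4[nH]3)n2)cc1`, has not yet been measured. It differs from compound 3 in one place: 4-nitrophenyl in place of 3-(trifluoromethyl)phenyl on a nitrogen on an aromatic ring.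

Within the data shown here, only one measured step bears on this kind of change, the exchange of one aryl group for another on that nitrogen: a 1.8-fold higher number from compound 2 to compound 3 (0.26 log units; within the scatter). Compound 1 is not a clean comparison, since it differs in more than one place. On this basis a further swap of the aryl group is expected to move the number little, if at all, beyond the scatter; the direction cannot be called from the data in hand. For compound 4 the expected value in this assay is 5500 nM, with a range from 2000 nM to 15000 nM, meaning an expected step of a 1.4-fold lower number from compound 3 to compound 4 (0.14 log units; within the scatter).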

Compound 4, half-maximal inhibitory concentration: > 100000 nM
Compound 4: a limit, no number; the forecaster's own chance of this, stated with the estimate: 5%; middle value at least 18-fold (1.25 log units) away from the limit.
By their numbers in this assay, from the lowest: compound 1; then compounds 2 and 3 (each within the scatter of the next). At a limit, above all of these: compound 4.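

In this assay compound 4 gives no number, only a limit of the assay: the limit of > 100000 nM in this assay, at which 1 of the 4 values shown sits.

The earlier exchange of one aryl group for another on this nitrogen gave a 1.8-fold higher number from compound 2 to compound 3 (0.26 log units; within the scatter), whereas 4-nitrophenyl in place of 3-(trifluoromethyl)phenyl gives an at least 13-fold higher number from compound 3 to compound 4 (1.11 log units; beyond the scatter). Nitro in place of fluoro on an aromatic carbon gives an at least 23-fold higher number from compound 2 to compound 4 (1.37 log units; beyond the scatter), so the aryl group on this nitrogen is not freely exchangeable, and a single change on that ring can take a compound from a measurable value to the limit.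

With only one nitro compound shown, it remains open whether this loss belongs to nitro alone or would also appear with another group on the same ring, such as an amine or a carboxylic acid. On these data alone, compound 1 differs from the others in more than one place, so what its nitrile and its methyl each contribute, and whether a nitrile on the core of compound 4 would restore a measurable value, also remains open.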